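Hydrazone series: a third hydroxy on the aryl ring

The compounds below may be only part of what the source reports. "The series", "measured", "known", "first", "only" and "open" are said of these compounds alone.

Measured so far in a physicochemical assay, read by spectrophotometry, with a stated time of 6 min; a lower number here means a stronger inhibitor, a higher number a weaker inhibitor:
compound 1, `COc1cc(/C=N/NC(=O)CCCc2nc3ccccc3c(=O)[nH]2)cc(O)c1O`, gives 50000000 nM
compound 2, `COc1ccc(/C=N/NC(=O)CCCc2nc3ccccc3c(=O)[nH]2)cc1`, gives 180000000 nM
compound 3, `O=C(CCCc1nc2ccccc2c(=O)[nH]1)N/N=C/c1ccc(O)c(O)c1`, gives 50000000 nM

Compound 3 stands level with compound 1 at the digits recorded, the two of them together the lowest of the three numbers; the step of no change at the digits printed from compound 1 to compound 3 (within the scatter) is within the scatter. Compound 2 sits furthest from it: the step of a 3.6-fold lower number from compound 2 to compound 3 (0.56 log units; beyond the scatter) is modest but beyond the scatter.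

Compound 4, `O=C(CCCc1nc2ccccc2c(=O)[nH]1)N/N=C/c1cc(O)c(O)c(O)c1`, is not yet measured. It differs from compound 3 by hydroxy in place of hydrogen on an aromatic carbon; cut one bond further out, the change reads 3,4-dihydroxyphenyl to 3,4,5-trihydroxyphenyl.

Within the data shown here, two measured steps bear on it. The step of a 3.6-fold lower number from compound 2 to compound 3 (0.56 log units; beyond the scatter) shows that putting hydroxy groups on this ring in place of methoxy lowered the number by a modest amount. The step of no change at the digits printed from compound 1 to compound 3 (within the scatter) shows that removing a methoxy from the ring left the number unchanged. Neither step adds a hydroxy to a ring that already carries two, so the third hydroxy is an extrapolation. The expectation is a small lowering or none beyond the scatter, written as a 1.7-fold lower number from compound 3 to compound 4 (0.22 log units; within the scatter). For compound 4 the estimate in this assay is 30000000 nM, with a range from 10000000 nM to 70000000 nM.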

Compound 4, half-maximal inhibitory concentration: 40000000 nM
For compound 4 the middle estimate is 1.3-fold (0.12 log units) below the measured one; low and high end bracket the measured number.
By their numbers in this assay, from the lowest: compounds 4, 1 and 3 (each within the scatter of the next); then compound 2.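

In this assay the position ortho to a hydroxy group now has a direct test on the 3,4-dihydroxyphenyl ring: the change to 3,4,5-trihydroxyphenyl gives a 1.3-fold lower number from compound 3 to compound 4 (0.10 log units; within the scatter) and so does not separate the two compounds. Hydroxy and methoxy at this place are not told apart either, with a 1.3-fold lower number from compound 1 to compound 4 (0.10 log units; within the scatter) for hydrogen in place of methyl on the oxygen, so hydrogen, hydroxy and methoxy all sit within the scatter here. Among these compounds, the only clear separation involving compound 4 is against the 4-methoxyphenyl ring, with a 4.5-fold lower number from compound 2 to compound 4 (0.65 log units; beyond the scatter) as a modest step beyond the scatter, and that step changes more than one place on the ring, so it cannot be credited to the added hydroxy alone.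

On these data alone, whether an amine or a carboxylic acid at this place would move the number beyond the scatter remains open, as does the effect of a longer chain between the shared core and the hydrazone. Nothing available explains why the number stays flat at this position.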